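A few compounds are considered here, and "the series" means these few. Any claim that something is new, unique, unknown or untested is made for them only; others in the source may bear on it.

Measured in a physicochemical assay for lipophilicity, at pH 7.4; a lower number here means a more polar compound, a higher number a more lipophilic compound:
compound 1, `Cc1cc(COc2ccccc2)nc(-c2ccccn2)n1`, gives 2.7
compound 2, `Cc1cc(COc2ccccc2F)nc(-c2ccccn2)n1`, gives 2.9
compound 3, `Cc1cc(COc2ccc(F)c(F)c2)nc(-c2ccccn2)n1`, gives 3.2

Notes. Compound 1 and compound 2 differ in one place: fluoro in place of hydrogen on an aromatic carbon. In this assay this gave a number 0.20 log units higher from compound 1 to compound 2 (within the scatter). Compound 3 carries two fluoro groups on the same ring; the difference between its core and that of compound 1 is not broken down here. Its value is the highest of the three, beyond the scatter from compound 1 but within it from compound 2.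

Compound 4, `Cc1cc(COc2cc(F)c(F)cc2F)nc(-c2ccccn2)n1`, is not yet measured. It differs from compound 3 in one place: fluoro in place of hydrogen on an aromatic carbon. This is the same kind of change as that from compound 1 to compound 2, though the surroundings differ: in compound 4 the entering fluoro is also meta to a fluoro group and para to a fluoro group, which is not so in compound 2. The step from compound 3 to compound 4 in this assay is expected to be a number 0.20 log units higher from compound 3 to compound 4 (within the scatter), resting on the earlier step of a number 0.20 log units higher from compound 1 to compound 2 (within the scatter) and on compound 3 standing at 3.2. Compound 4 is therefore estimated at 3.4, likely between 3.1 and 3.7.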

Compound 4, distribution coefficient: 3.2
For compound 4 the middle estimate is 0.20 log units above the measured one, and the stated range covers the measured number.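

In this assay, fluoro in place of hydrogen on an aromatic carbon gave no change at the digits printed from compound 3 to compound 4 (within the scatter), and in the core of compound 1 the same change gave a number 0.20 log units higher from compound 1 to compound 2 (within the scatter), so neither core shows a step beyond the scatter. These two steps do not show that the change is without effect across the series, or that a step of one size carries from core to core: the entering fluoro in compound 4 is meta to a fluoro group and para to a fluoro group, which is not so in compound 2, and steps within the scatter cannot tell these surroundings apart. Nothing measured here bears on why the steps came out as they did.

The compounds shown leave open how an amine, a carboxylic acid or a methoxy group on the same ring would read in this assay and whether such a group would move the number beyond the scatter. They also leave open what fluoro does on the other rings of the shared core.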